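The compounds below may be only part of what the source reports. "The series", "measured", "known", "first", "only" and "open" are said of these compounds alone.

In a functional assay on A549 cells (Homo sapiens) for inhibition, read by CCK-8 assay, with a stated time of 48 h (a higher number here means a weaker inhibitor, a lower number a stronger inhibitor), compound 1 (`COc1cc(-c2ccnc3cc(-c4ccccc4)nn23)cc(OC)c1OC`) gives 208 nM, compound 2 (`COc1cc(-c2ccnc3cc(-c4ccc5ccn(C)c5c4)nn23)cc(OC)c1OC`) gives 829 nM and compound 3 (`COc1ccc(-c2cc3nccc(-c4cc(OC)c(OC)c(OC)c4)n3n2)cc1`) gives 376 nM. Compound 3 lies within the scatter of compound 1, while compound 2 stands apart from it, with a 2.2-fold lower number from compound 2 to compound 3 (0.34 log units; beyond the scatter). The unmeasured compound 4 (`COc1cc(-c2ccnc3cc(-c4ccc5cnn(C)c5c4)nn23)cc(OC)c1OC`) carries 1-methyl-1H-indazol-6-yl in place of the 4-methoxyphenyl of compound 3, on an aromatic carbon of a five-membered aromatic ring with 2 nitrogen: 1-methyl-1H-indazol-6-yl in place of 4-methoxyphenyl on an aromatic carbon.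

The closest evidence is the 1-methyl-1H-indol-6-yl of compound 2, the nearest relative of the entering group. Putting that group in place of phenyl gave a 4.0-fold higher number from compound 1 to compound 2 (0.60 log units; beyond the scatter), and exchanging it for 4-methoxyphenyl gave a 2.2-fold lower number from compound 2 to compound 3 (0.34 log units; beyond the scatter). The methoxy step, a 1.8-fold higher number from compound 1 to compound 3 (0.26 log units; within the scatter), adds little. A modest move to a higher number is therefore expected in this assay, though no indazole has yet been measured. The expected change is a 1.9-fold higher number from compound 3 to compound 4 (0.27 log units; within the scatter). For compound 4, the estimated value is 700 nM, with an expected range of 260 nM to 1900 nM.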

Compound 4, half-maximal inhibitory concentration: 233 nM
Estimate against measurement, compound 4: 3.0-fold (0.48 log units) above; measured number outside the range, below it.
By their numbers in this assay, from the lowest: compounds 1, 4 and 3 (each within the scatter of the next); then compound 2.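

A two-ring group does not by itself raise the number at this position, on an aromatic carbon of a five-membered aromatic ring with 2 nitrogen: in this assay, 1-methyl-1H-indazol-6-yl stays level with phenyl (a 1.1-fold higher number from compound 1 to compound 4 (0.05 log units; within the scatter)) and with 4-methoxyphenyl (a 1.6-fold lower number from compound 3 to compound 4 (0.21 log units; within the scatter)). The higher number of compound 2 is thus tied to 1-methyl-1H-indol-6-yl specifically and not to two-ring groups in general, since exchanging that group for its indazole relative gives a 3.6-fold lower number from compound 2 to compound 4 (0.55 log units; beyond the scatter) on the same core. Nothing available accounts for the gap between these two closely related groups.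

Still open, going by these compounds, is whether other two-ring groups at this place follow the indazole or the indole. On these data alone, it is also open whether a group of another kind there, such as an amine, a carboxylic acid or a morpholine, would keep the number in this range.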